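This account rests on a few compounds, and the source may have more. Where it says the series, first, only, none or still open, it means among the compounds named here.

Two compounds sharing a common core have been examined in a functional assay on BJAB cells (Homo sapiens) for antiproliferative activity, with a stated time of 4 days; on this read-out lower numbers stand for an effect already at smaller amounts and higher numbers for an effect only at larger amounts of compound. Compound 1 `COc1cc(C#N)cc(-c2c(C)nn(-c3nc(-c4ccc(Cl)c(Cl)c4)c(SC(C)C)s3)c2C(=O)O)c1` gives 5200 nM in this assay. For the measured compounds named here, compound 2 `Cc1nn(-c2nc(-c3ccc(Cl)c(Cl)c3)c(SC(C)C)s2)c(C(=O)O)c1-c1cccnc1` gives 12000 nM in this assay, the higher of the two numbers measured so far; its only neighbour is compound 1, and the single step that joins them, a 2.3-fold higher number from compound 1 to compound 2 (0.36 log units; beyond the scatter), came from the exchange of a 3-cyano-5-methoxyphenyl for a pyridin-3-yl on an aromatic carbon.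

Compound 3 `COc1ccc(C)cc1-c1c(C)nn(-c2nc(-c3ccc(Cl)c(Cl)c3)c(SC(C)C)s2)c1C(=O)O` has not yet been measured. It differs from compound 2 in one place: 2-methoxy-5-methylphenyl in place of pyridin-3-yl on an aromatic carbon. Going by the values given here, the change thus reverses the direction of the only measured step, since a pyridin-3-yl is again replaced by a substituted six-membered carbon ring, though the substituents now differ from those of compound 1. Among the compounds with values here, on that single step, a modest lowering of the number is expected for compound 3, in the order of the step of a 2.3-fold higher number from compound 1 to compound 2 (0.36 log units; beyond the scatter) run backwards, with wide uncertainty because only one comparison exists. The expected step is a 2.2-fold lower number from compound 2 to compound 3 (0.34 log units; beyond the scatter). Compound 3 is therefore estimated at 5500 nM in this assay, within a range from 1500 nM to 18000 nM.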

Compound 3, half-maximal effective concentration: 9500 nM
Beside the measured number, compound 3's estimate is 1.7-fold (0.24 log units) below it; measured number inside the range.
By their numbers in this assay, from the lowest: compounds 1, 3 and 2 (each within the scatter of the next, the first and the last beyond it).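

In this assay, putting 2-methoxy-5-methylphenyl, with 9 heavy atoms, in place of pyridin-3-yl, with 6, on this aromatic carbon gives a 1.3-fold lower number from compound 2 to compound 3 (0.10 log units; within the scatter), so the larger carbon-only ring, with its methoxy and methyl substituents, cannot be told apart from the pyridine here. For the compounds shown here, exchanging the 3-cyano-5-methoxyphenyl for the same group gives a 1.8-fold higher number from compound 1 to compound 3 (0.26 log units; within the scatter), so compound 3 sits within the scatter of both earlier compounds, and the one step beyond the scatter, between compound 1 and compound 2, is no longer evidence that a substituted carbon-only ring as such sets the level at this position. Nothing available offers an explanation for these readings.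

On these data alone, the three compounds differ only on this one carbon and carry only cyano, methoxy and methyl substituents or a ring nitrogen, so it remains open whether an unsubstituted phenyl, or a ring bearing an amine or a hydroxy group, would stay within this narrow band. As far as these compounds go, it is equally open whether the pattern holds when the neighbouring carboxy or methyl group on the shared core is replaced, for instance by an amide or an ethyl group.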